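The source may report more compounds than this note shows. Statements on the series, on what has been measured and on what is new or still open speak of the compounds shown alone.

Measured compounds:
compound 1 `O=C(Cn1ccnc1)N1CCC(NS(=O)(=O)c2cc(S(=O)(=O)c3ccccc3)ccc2C(F)(F)F)CC1` with 230 nM
compound 2 `O=C([C@@H]1CCCN1C(=O)c1ccncc1)N1CCC(NS(=O)(=O)c2cc(S(=O)(=O)c3ccccc3)ccc2C(F)(F)F)CC1` with 350 nM

In a functional assay on U2OS cells for antagonist activity at proto-oncogene Wnt-3 (Homo sapiens), read by a luciferase reporter, with a stated time of 18 h (on this read-out lower numbers stand for an effect already at smaller amounts and higher numbers for an effect only at larger amounts of compound), compound 1 gives 230 nM, and compound 2 gives 350 nM. Compound 1 has the lowest of the two numbers, but its nearest neighbour, compound 2, lies within the scatter of it, so the two values tell the same story and neither compound can be called the more potent. Compound 3 `O=C([C@@H]1CCCN1Cc1ccccc1)N1CCC(NS(=O)(=O)c2cc(S(=O)(=O)c3ccccc3)ccc2C(F)(F)F)CC1` has not been measured. It differs from compound 1 in one place: 1-benzylpyrrolidin-2-yl in place of (1H-imidazol-1-yl)methyl on a carbonyl carbon. Among the measured compounds shown here, no step between two measured compounds covers this exact change, so the size of the step can only be expected, not read off. Because compound 2 carries a related pyrrolidinyl group on the same carbonyl carbon and gives 350 nM, a step from compound 1 to compound 3 in this assay of no more than modest size, if any beyond the scatter, is expected, a 1.7-fold higher number from compound 1 to compound 3 (0.24 log units; within the scatter). For compound 3 the estimate in this assay is 400 nM, within a range from 130 nM to 1200 nM.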

Compound 3, half-maximal effective concentration: 720 nM
The estimate for compound 3 lay 1.8-fold (0.26 log units) below the measured number; the range from low to high includes it.
By their numbers in this assay, from the lowest: compounds 1 and 2 (each within the scatter of the next); then compound 3.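

In this assay the carbonyl carbon proves not to accept every group alike: 1-benzylpyrrolidin-2-yl in place of (1H-imidazol-1-yl)methyl gives a 3.1-fold higher number from compound 1 to compound 3 (0.50 log units; beyond the scatter) and so moves the number beyond the scatter, which the two earlier compounds, with their different groups at this place, did not do. Benzyl in place of (pyridin-4-yl)carbonyl on an amine nitrogen in a ring gives a 2.1-fold higher number from compound 2 to compound 3 (0.31 log units; beyond the scatter), so the number depends on what that nitrogen carries and not on the pyrrolidine ring alone. Nothing available gives a reason for either step.

The compounds shown leave open how a methyl or an acetyl on that amine nitrogen would read, and so whether the phenyl ring or the missing carbonyl goes with the higher number. On these data alone, the opposite configuration at the defined stereocentre also remains open.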